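A Cyano Group Added to a Rapidly Cleared Urea

This account rests on a few compounds, and the source may have more. Where it says the series, first, only, none or still open, it means among the compounds named here.

Measured compounds:
compound 1 `O=C(Nc1cccnc1-c1ccccc1)N1CCN2C(=O)N([C@H]3C[C@@H]3c3ccccc3)C(=O)[C@@H]2C1`: 45000 mL.min-1.g-1
compound 2 `O=C(Nc1ccnn1-c1cccc(Cl)c1)N1CCN2C(=O)N([C@H]3C[C@@H]3c3ccccc3)C(=O)[C@@H]2C1`: 62000 mL.min-1.g-1

In an in vitro ADME assay on microsomes from liver (Homo sapiens) for metabolic stability (on this read-out higher numbers stand for fast clearance and lower numbers for slow clearance), compound 1 gives 45000 mL.min-1.g-1, the lower of the two numbers shown, while compound 2 gives 62000 mL.min-1.g-1; the gap between them lies within the scatter. Compound 3 `N#Cc1cccc(-c2ncccc2NC(=O)N2CCN3C(=O)N([C@H]4C[C@@H]4c4ccccc4)C(=O)[C@@H]3C2)c1` differs from compound 1 by cyano in place of hydrogen on an aromatic carbon. Among the compounds with values here, no pair of measured compounds shows what this change does in this assay. Compound 3 is expected to remain close to compound 1, with an estimated step of a 1.3-fold lower number from compound 1 to compound 3 (0.11 log units; within the scatter) leaning toward slower clearance but not clearly beyond the scatter. The estimate for compound 3 is 35000 mL.min-1.g-1, between 15000 mL.min-1.g-1 and 80000 mL.min-1.g-1.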

Compound 3, intrinsic clearance in microsomes: 37000 mL.min-1.g-1
Estimate against measurement, compound 3: 1.1-fold (0.02 log units) below, and the stated range covers the measured number.
By their numbers in this assay, from the lowest: compounds 3, 1 and 2 (each within the scatter of the next).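

In this assay, cyano in place of hydrogen on an aromatic carbon, meta to a large group, gives a 1.2-fold lower number from compound 1 to compound 3 (0.09 log units; within the scatter), which lies within the scatter. Within the data shown here, this single pair is the first direct reading of the change, and it shows no clear shift in clearance at this position. Nothing measured here offers an explanation for this result.

As far as these compounds go, whether an amine, a carboxylic acid or a methoxy group at this place would move the number beyond the scatter remains open. So does whether cyano would behave the same on another carbon of that ring or on the chlorophenyl ring of compound 2.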